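A few compounds are considered here, and "the series" means these few. Any claim that something is new, unique, unknown or untested is made for them only; others in the source may bear on it.

Measured compounds in a functional assay on HeLa cells (Homo sapiens) for antiproliferative activity, read by CCK-8 assay, with a stated time of 72 h, tested at 2 uM; a lower number here means a weaker effect, a higher number a stronger effect of the compound at the concentration tested:
Compound 1 `CC1CCCCN1C(=S)SCc1ccc(C(=O)Nc2ccccc2N)cc1` gives 45.5%.
Compound 2 `CCN(Cc1ccncc1)C(=S)SCc1ccc(C(=O)Nc2ccccc2N)cc1` gives 63.5%.
Compound 3 `CC1CCN(C(=S)SCc2ccc(C(=O)Nc3ccccc3N)cc2)CC1` gives 46.8%.

Among these three, compound 3 sits second highest, separated from compound 1 only within the scatter, and from compound 2 by a modest gap. Among the compounds with values here, the one unmeasured compound is compound 4 `CN(Cc1cccnc1)C(=S)SCc1ccc(C(=O)Nc2ccccc2N)cc1`, which differs from compound 3 in one place: methyl((pyridin-3-yl)methyl)amino in place of 4-methylpiperidin-1-yl on a thiocarbonyl carbon. Within the data shown here, two measured steps bear on this. The change a number 1.3 percentage points higher from compound 1 to compound 3 (within the scatter) shows that moving a methyl around the piperidine ring hardly matters. The change a number 16.7 percentage points lower from compound 2 to compound 3 (beyond the scatter) shows that replacing an open-chain amine carrying a pyridine with a methylpiperidine lowers inhibition modestly. Compound 4 returns to an open-chain amine carrying a pyridine, so a modest rise is expected, a number 11.2 percentage points higher from compound 3 to compound 4 (beyond the scatter). Compound 4 is therefore estimated at 58%, within 45% to 70%.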

Compound 4, a percentage reported as inhibition, at one concentration (the size of the read-out at that concentration, not a potency): 16.4%
Estimate against measurement, compound 4: 41.6 percentage points above, outside the stated range (below it).
By their numbers in this assay, from the lowest: compound 4; then compounds 1 and 3 (each within the scatter of the next); then compound 2.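

In this assay an open-chain amine carrying a pyridine on the thiocarbonyl carbon does not by itself raise the number: the change gives a number 30.4 percentage points lower from compound 3 to compound 4 (beyond the scatter) and likewise a number 29.1 percentage points lower from compound 1 to compound 4 (beyond the scatter). The largest step lies within the pyridine-bearing amines, with a number 47.1 percentage points lower from compound 2 to compound 4 (beyond the scatter), so this position separates even two closely related groups sharply. Nothing available explains the drop.

Going by these compounds, compounds 2 and 4 differ in both the ethyl or methyl on nitrogen and the pyridine attachment, so which of these matters stays open. Ethyl((pyridin-3-yl)methyl)amino would separate the two.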